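The source may report more compounds than this note shows. Statements on the series, on what has been measured and on what is new or still open speak of the compounds shown alone.

Three compounds share one core. Compound 1 `Fc1cccc(Cl)c1CNc1ccc(Oc2cc(C(F)(F)F)cc(C(F)(F)F)c2)cc1` gives in an assay on HEK293 cells for inhibition of Toll-like receptor 8 (Homo sapiens), with a stated time of 16 h (on this read-out lower numbers stand for stronger inhibition and higher numbers for weaker inhibition), only a limit, > 50000 nM. Compound 2 `O=C(Nc1ccc(Oc2cc(C(F)(F)F)cc(C(F)(F)F)c2)cc1)c1sccc1Cl` gives 3200 nM in this assay. Compound 3 `O=C(Nc1ccc(Oc2cc(F)cc(C(F)(F)F)c2)cc1)c1c(F)cccc1Cl` gives 1590 nM in this assay, the lowest of the two numbers shown, though compound 2 lies within the scatter of it. Within the data shown here, the single measured step, an at least 15-fold lower number from compound 1 to compound 2 (1.19 log units; beyond the scatter), concerns a different place and a different kind of exchange, and the third value, that of compound 1, is only a limit (the limit of > 50000 nM in this assay, at which 1 of the 3 values shown sits). Compound 4 `O=C(Nc1ccc(Oc2cc(Br)cc(C(F)(F)F)c2)cc1)c1c(F)cccc1Cl` differs from compound 3 by bromo in place of fluoro on an aromatic carbon. No measured step bears on this change, and none of the shown compounds varies this position against a fixed rest. A step within the scatter is therefore the expectation, in neither direction. The step from compound 3 to compound 4 is expected to be a 1.2-fold lower number from compound 3 to compound 4 (0.09 log units; within the scatter). For compound 4 the estimate in this assay is 1300 nM, with a range from 400 nM to 4500 nM.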

Compound 4, half-maximal inhibitory concentration: 2320 nM
Compound 4: middle estimate off by 1.8-fold (0.25 log units), on the low side, and the stated range covers the measured number.
By their numbers in this assay, from the lowest: compounds 3, 4 and 2 (each within the scatter of the next). At a limit, above all of these: compound 1.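

In this assay bromo in place of fluoro on an aromatic carbon meta to a trifluoromethyl group gives a 1.5-fold higher number from compound 3 to compound 4 (0.16 log units; within the scatter), the first step shown that varies this position against a fixed rest. This assay therefore does not tell these two substituents apart at this position, with the rest of the molecule held constant. Nothing measured here gives a reason for this result.

Going by these compounds, whether this tolerance extends beyond fluoro and bromo remains open, since a hydroxyl, an amine, a carboxylic acid or a longer chain such as propyl at this position could give a quite different number. Also open, on these data alone, is whether the same exchange would give a similar step with the (3-chlorothiophen-2-yl)carbonyl group of compound 2 on the nitrogen.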